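The source may report more compounds than this note shows. Statements on the series, on what has been measured and on what is new or still open speak of the compounds shown alone.

Compound 3 `O=S(=O)(Nc1cc(-c2cnc3[nH]cc(-c4ccncc4)c3c2)cnc1Cl)c1ccc(F)cc1` stands at the highest of the two numbers in a functional assay on MCF7 cells (Homo sapiens) for inhibition, read by sulforhodamine B assay, with a stated time of 72 h (on this read-out lower numbers stand for stronger inhibition of growth and higher numbers for weaker inhibition of growth), giving 2910 nM. Compound 1 `O=S(=O)(Nc1cc(-c2cnc3[nH]cc(-c4ccncc4)c3c2)cnc1Cl)c1ccccc1F` gives 2500 nM in this assay, and the step of a 1.2-fold higher number from compound 1 to compound 3 (0.07 log units; within the scatter) is within the scatter. Compound 2 `O=S(=O)(Nc1cc(-c2cnc3[nH]cc(-c4ccccc4)c3c2)cnc1Cl)c1ccccc1` shows only a limit in this assay, > 10000 nM, which is the limit of > 10000 nM in this assay, at which 1 of the 3 values shown sits. Compound 4 `O=S(=O)(Nc1cc(-c2cnc3[nH]cc(-c4ccncc4)c3c2)cnc1Cl)c1ccccc1` differs from compound 3 by hydrogen in place of fluoro on an aromatic carbon. Among the compounds with values here, the one measured step that concerns the fluorine, moving it around the same ring, was a 1.2-fold higher number from compound 1 to compound 3 (0.07 log units; within the scatter) and stayed within the scatter, so removing it is expected to give no step beyond the scatter either. Compound 4 is therefore estimated at 2900 nM in this assay, with a range of 1200 nM to 7000 nM. The expected step is a 1.0-fold lower number from compound 3 to compound 4 (0.00 log units; within the scatter).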

Compound 4, concentration for 50% growth inhibition: 2140 nM
Compound 4: the middle estimate sits 1.4-fold (0.13 log units) above what was measured; the range from low to high includes it.
By their numbers in this assay, from the lowest: compounds 4, 1 and 3 (each within the scatter of the next). At a limit, above all of these: compound 2.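

Hydrogen in place of fluoro gives a 1.4-fold lower number from compound 3 to compound 4 (0.13 log units; within the scatter) and a 1.2-fold lower number from compound 1 to compound 4 (0.07 log units; within the scatter), so in this assay the phenylsulfonyl group of compound 4 serves as well as either fluorinated one. Within the data shown here, compound 4 also gives compound 2 its first partner differing in one place, and pyridin-4-yl in place of phenyl gives an at least 4.6-fold lower number from compound 2 to compound 4 (0.66 log units; beyond the scatter), the only step here beyond the scatter. Compound 2 stands at a limit, so that step has no upper bound: the limit of > 10000 nM in this assay, at which 1 of the 4 values shown sits.

Open, from the compounds shown here alone, is whether a methoxy group or an amine on the sulfonyl phenyl ring would move the number. Also open, going by these compounds, is whether a pyridin-3-yl or a morpholine could replace the pyridin-4-yl.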